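A few compounds are considered here, and "the series" means these few. Any claim that something is new, unique, unknown or untested is made for them only; others in the source may bear on it.

In a functional assay on HT-29 cells (Homo sapiens) for inhibition, read by CCK-8 assay, with a stated time of 24 h (a higher number here means a weaker inhibitor, a lower number a stronger inhibitor), compound 1 `O=C1Nc2ccccc2/C1=C/c1ccc(-c2cn(-c3cccc(Cl)c3)nn2)cc1` reads > 20000 nM, which is a limit of the assay and not a number. Compound 2 `O=C1Nc2ccc(F)cc2/C1=C/c1ccc(-c2cn(-c3ccccc3F)nn2)cc1` gives 8980 nM, and compound 3 `O=C1Nc2ccc(F)cc2/C1=C/c1ccc(-c2cn(-c3ccc(F)cc3)nn2)cc1` gives 20000 nM, the higher of these two numbers. Compound 4 `O=C1Nc2ccc(F)cc2/C1=C/c1ccc(-c2cn(-c3cccc(Cl)c3)nn2)cc1` has 3-chlorophenyl in place of 4-fluorophenyl on an aromatic nitrogen. Among the measured compounds shown here, the only measured step at this place swaps 2-fluorophenyl for 4-fluorophenyl, and it is modest: a 2.2-fold higher number from compound 2 to compound 3 (0.35 log units; beyond the scatter). For the measured compounds named here, compound 1 also carries 3-chlorophenyl, but its limit gives no size of step. A similarly small change, towards a slightly lower number, is therefore expected, possibly none beyond the scatter: a 1.4-fold lower number from compound 3 to compound 4 (0.15 log units; within the scatter). For compound 4 the estimated value is 14000 nM, with an expected range of 6000 nM to 30000 nM.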

Compound 4, half-maximal inhibitory concentration: 10500 nM
The estimate for compound 4 lay 1.3-fold (0.12 log units) above the measured number; the measured number falls inside the stated range.
By their numbers in this assay, from the lowest: compounds 2, 4 and 3 (each within the scatter of the next, the first and the last beyond it).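

Moving to 3-chlorophenyl on this aromatic nitrogen gives a change within the scatter against either fluorophenyl group (a 1.9-fold lower number from compound 3 to compound 4 (0.28 log units; within the scatter); a 1.2-fold higher number from compound 2 to compound 4 (0.07 log units; within the scatter)), so compound 4 does not separate from compound 2 or compound 3. The fluoro on the core gives an at least 1.9-fold lower number from compound 1 to compound 4 (0.27 log units; that floor lies within the scatter), a floor that shows no clear gain from fluoro. On these data alone, compound 1 stands at a limit, not a number, so the true size of that step stays unknown: the limit of > 20000 nM in this assay, at which 1 of the 4 values shown sits.

Every group shown on this nitrogen is a halogen-bearing phenyl, so the effect of an amine, a carboxylic acid or a longer chain there remains open.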